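This account rests on a few compounds, and the source may have more. Where it says the series, first, only, none or still open, it means among the compounds named here.

Measured in an assay on brain for displacement of a labelled ligand from Adrenergic receptor alpha-1 (Rattus norvegicus); a higher number here means a weaker inhibitor, a lower number a stronger inhibitor:
compound 1 `COc1cc2nc(N3CCN(c4nccc(N(C)C)n4)CC3)cc(N)c2cc1OC`: 0.46 nM
compound 2 `COc1cc2nc(N(C)C)cc(N)c2cc1OC`: 11.4 nM
compound 3 `COc1cc2nc(N3CCN(c4ccccc4)CC3)cc(N)c2cc1OC`: 1.72 nM

Within the data shown here, compound 3 holds the second highest of the three numbers; the single measured step is a 3.7-fold higher number from compound 1 to compound 3 (0.57 log units; beyond the scatter), and compound 2 gives the highest number of the three.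

Compound 4 `CCCNC(=O)N1CCN(c2cc(N)c3cc(OC)c(OC)cc3n2)CC1` differs from compound 3 by propylcarbamoyl in place of phenyl on an amine nitrogen in a ring. Among the measured compounds shown here, the only measured step at this ring nitrogen exchanges one aromatic group for another and is modest; no measured step replaces the phenyl with a group that has no ring, so this change is uncharted. For the measured compounds named here, compound 2 at 11.4 nM against compound 3 at 1.72 nM shows only that removing the whole ring with its substituent raises the number. For compound 4 the expected step is a 1.7-fold higher number from compound 3 to compound 4 (0.24 log units; within the scatter), a small rise or none beyond the scatter. Compound 4 is estimated at 3 nM, range 0.8 nM to 12 nM.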

Compound 4, inhibition constant: 0.44 nM
Estimate against measurement, compound 4: 6.8-fold (0.83 log units) above; measured number outside the range, below it.
By their numbers in this assay, from the lowest: compounds 4 and 1 (each within the scatter of the next); then compound 3; then compound 2.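

On this amine nitrogen in a ring, an aromatic group is not required for a low number in this assay: propylcarbamoyl, with no ring, gives (a 3.9-fold lower number from compound 3 to compound 4 (0.59 log units; beyond the scatter)). The comparison with the 4-(dimethylamino)pyrimidin-2-yl group gives (a 1.0-fold lower number from compound 1 to compound 4 (0.02 log units; within the scatter)), so these two groups cannot be told apart here. Nothing available explains either step.

Still open, as far as these compounds go, is whether a chain longer than propyl keeps the number at this level. Also open, from the compounds shown here alone, is whether the amide hydrogen matters, which a version carrying a methyl group on that nitrogen would test.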